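A few compounds are considered here, and "the series" means these few. Any claim that something is new, unique, unknown or untested is made for them only; others in the source may bear on it.

Measured so far, all in a functional assay, tested at 100 ug/mL; a higher number here means a weaker effect of the compound at the concentration tested, a lower number a stronger effect:
Compound 1 `CCOC(=O)C1=C(C)N(c2ccccc2)C=CC1c1ccccc1`: -21.5%
Compound 2 `COC(=O)C1=C(C)N(c2ccccc2)C=CC1c1ccccc1`: -25.9%
Compound 3 `COC(=O)C1=C(C)N(c2ccccc2)C=C(C)C1c1ccccc1`: -21.1%

Compound 3 sits alongside the other two: its gap to compound 1 and the step of a number 4.8 percentage points higher from compound 2 to compound 3 (within the scatter) both fall inside the usual scatter, so no ordering among the three can be read from this assay. The step of a number 4.4 percentage points lower from compound 1 to compound 2 (within the scatter) exchanged the alkyl of the ester, and the step of a number 4.8 percentage points higher from compound 2 to compound 3 (within the scatter) placed a methyl on a double-bonded ring carbon; neither moved the read-out beyond the scatter.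

Compound 4 `COC(=O)C1=C(C)N(c2cccc(C)c2C)C=C(C)C1c1ccccc1` differs from compound 3 by 2,3-dimethylphenyl in place of phenyl on an amine nitrogen in a ring. For the measured compounds named here, no measured step touches the aryl group on the amine nitrogen in the ring, so nothing measured bears directly on this change. Going by the values given here, the only guidance is indirect: the two changes made so far, a number 4.4 percentage points lower from compound 1 to compound 2 (within the scatter) and a number 4.8 percentage points higher from compound 2 to compound 3 (within the scatter), left this assay flat, and the shared core is kept intact. A reading near the three measured values is therefore expected, with no step beyond the scatter. Compound 4 is estimated at -21%, in the range -38% to -4%. Among the compounds with values here, the implied step a number 0.1 percentage points higher from compound 3 to compound 4 (within the scatter) is expected to stay within the scatter; the range is set wide since no measured step alters the group on the nitrogen.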

Compound 4, a percentage reported as activity, at one concentration (the size of the read-out at that concentration, not a potency): -23.6%
For compound 4 the middle estimate is 2.6 percentage points above the measured one, within the range that was stated.
By their numbers in this assay, from the lowest: compounds 2, 4, 1 and 3 (each within the scatter of the next).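

For the compounds shown here, the aryl group on the amine nitrogen in a ring is changed here for the first time: in this assay, 2,3-dimethylphenyl in place of phenyl gives a number 2.5 percentage points lower from compound 3 to compound 4 (within the scatter). This position therefore tolerates the larger 2,3-dimethylphenyl group in this read-out, and it becomes the third place on the shared core where a single change stays within the scatter, after the ester alkyl and the double-bonded ring carbon. No supporting data are available to explain this result or to assign any property to the group.

Still open, from the compounds shown here alone, is whether the read-out in this assay would stay flat with a carboxylic acid or an amine on the aryl ring, or with a longer alkyl chain replacing the aryl group on the nitrogen. Also open, going by these compounds, is what a change at the ring atom bearing the phenyl group would do, and, with a single tested concentration, how these compounds compare in potency.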